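Shrinking the Amide Substituent on a Piperidine Side Chain

The source may hold more compounds than are shown below. What is called first, only, known or untested is meant among the compounds shown, and "the series" means these compounds.

Measured compounds:
- Compound 1, `CC(C)n1nc(-c2ccnc3[nH]c(C4CCN(CC(=O)N(C)C)CC4)cc23)ccc1=O`: 2.9 L/kg
- Compound 2, `CC(C)n1cc(-c2ccnc3[nH]c(C4CCN(CC(=O)N5CCCCC5)CC4)cc23)ccc1=O`: 8.1 L/kg
- Compound 3, `COc1cc(F)ccc1-c1ccnc2[nH]c(C3CCN(C(C)=O)CC3)cc12`: 1.7 L/kg

All three numbers come from an ADME assay (Rattus norvegicus, strain Han-wistar) for pharmacokinetics, at a dose of 1.5 umol/kg by the intravenous route; a higher number here means that more of the compound sits outside the plasma, a lower number that more of the compound stays in the plasma. Within this small set compound 2 stands at the top: in this assay compound 2 gives 8.1 L/kg, a value beyond the scatter above both compound 1 and compound 3. The nearest number belongs to compound 1, which in this assay gives 2.9 L/kg; the furthest belongs to compound 3, which gives 1.7 L/kg.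

The next compound, compound 4, `CNC(=O)CN1CCC(c2cc3c(-c4ccc(=O)n(C(C)C)c4)ccnc3[nH]2)CC1`, has not yet been measured in this assay. It shares the core of compound 2 and differs from it in one place, on the carbonyl carbon of the side chain: methylamino in place of piperidin-1-yl on a carbonyl carbon. Among the compounds with values here, no measured pair in the set carries exactly this change, so the expectation rests on the spread of the numbers already seen.

Compound 1, with its smaller amide, sits well below compound 2, so a step downward beyond the scatter is expected here, of the size a 2.7-fold lower number from compound 2 to compound 4 (0.43 log units; beyond the scatter). On that basis compound 4 is estimated to give 3 L/kg in this assay, with a likely range from 1.5 L/kg to 6 L/kg.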

Compound 4, volume of distribution: 2.6 L/kg
Compound 4: the middle estimate sits 1.2-fold (0.06 log units) above what was measured, within the range that was stated.
By their numbers in this assay, from the lowest: compounds 3, 4 and 1 (each within the scatter of the next); then compound 2.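

Within the data shown here, this is the first pair in the set that differs in one place only, so the end of the side chain can now be read on its own. In this assay, methylamino in place of piperidin-1-yl on a carbonyl carbon gives a 3.1-fold lower number from compound 2 to compound 4 (0.49 log units; beyond the scatter), a step beyond the usual scatter. The swap removes the six-membered non-aromatic ring, goes from 6 heavy atoms to 2 and adds a hydrogen-bond donor, and this one pair cannot tell which of these changes goes with the lower number. No measurement available here explains the step.

Still open, on these data alone, is whether the ring or the amide hydrogen matters more: dimethylamino on this same core has neither, while pyrrolidin-1-yl keeps a ring with no amide hydrogen, so each would help pull the two apart. As far as these compounds go, it is also open how far the trend runs on this carbonyl carbon, for instance with a plain amino group or with a longer chain on the amide nitrogen.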